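Bromo on the benzoyl ring of compound 2

The source may report more compounds than this note shows. Statements on the series, on what has been measured and on what is new or still open speak of the compounds shown alone.

Going by the values given here, compound 2 `CC1(C)c2[nH]nc(NC(=O)c3ccccc3)c2CN1Cc1cccc(F)c1F` gives 200 nM in an assay on Sf21 cells for inhibition of high affinity nerve growth factor receptor (Homo sapiens), read by HTRF, with a stated time of 30 min, in the presence of a further agent that is not named here (on this read-out lower numbers stand for stronger inhibition and higher numbers for weaker inhibition), the lowest of the two numbers so far. Among the compounds with values here, compound 1 `CC1(C)c2[nH]nc(NC(=O)c3ccccc3)c2CN1Cc1cccc(I)c1` gives 1360 nM in this assay; the step of a 6.8-fold lower number from compound 1 to compound 2 (0.83 log units; beyond the scatter) is the only measured step, and it concerns the group on the saturated chain carbon bound to the amine nitrogen in a ring, not the benzoyl ring. Compound 3 `CC1(C)c2[nH]nc(NC(=O)c3ccc(Br)cc3)c2CN1Cc1cccc(F)c1F` carries the change (bromo in place of hydrogen on an aromatic carbon), on the benzoyl side of the shared core. Within the data shown here, no measured pair differs at that ring, so nothing bears directly on the new change. Among the measured compounds shown here, with no guidance from comparable steps, the expectation for compound 3 is a step of no size beyond the scatter, in either direction, a 1.1-fold higher number from compound 2 to compound 3 (0.04 log units; within the scatter). Compound 3 is therefore estimated at 220 nM, with a range from 70 nM to 700 nM, the width reflecting the absence of any comparable step.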

Compound 3, half-maximal inhibitory concentration: 950 nM
Compound 3: middle estimate off by 4.3-fold (0.64 log units), on the low side; the whole stated range lies below it.
By their numbers in this assay, from the lowest: compound 2; then compounds 3 and 1 (each within the scatter of the next).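

The benzoyl ring, which the earlier pair left untouched, is not indifferent to substitution: in this assay, bromo in place of hydrogen, para to a large group, gives a 4.8-fold higher number from compound 2 to compound 3 (0.68 log units; beyond the scatter) on the 2,3-difluorophenyl background. This first measured step at this ring runs towards weaker inhibition, and one added heavy atom is enough to take it beyond the scatter. No available evidence bears on the origin of this step.

As far as these compounds go, whether the loss is specific to bromo remains open, since the effect of fluoro, methoxy or an amine at this place on the benzoyl ring is unknown. From the compounds shown here alone, it is also open whether bromo would give a step of similar size alongside the 3-iodophenyl group of compound 1.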